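Biaryl amide series: heteroaryl swap at the distal ring

The compounds below may be only part of what the source reports. "The series", "measured", "known", "first", "only" and "open" are said of these compounds alone.

Measured so far:
compound 1 `CC(C)(C)c1ccc(NC(=O)c2ccc(-c3ccccc3)cc2)cc1`, 3600 nM
compound 2 `CC(C)(C)c1ccc(NC(=O)c2ccc(-c3ncccn3)cc2)cc1`, 60 nM

Within the data shown here, in a functional assay on Dorsal root ganglion for antagonist activity at transient receptor potential cation channel subfamily V member 1 (Rattus norvegicus) (on this read-out higher numbers stand for weaker inhibition and lower numbers for stronger inhibition), compound 2 holds the lowest number of the two; the only neighbour is compound 1, and the step of a 60-fold lower number from compound 1 to compound 2 (1.78 log units; beyond the scatter) was large. Compound 3 `CC(C)(C)c1ccc(NC(=O)c2ccc(-c3cnccn3)cc2)cc1` carries pyrazin-2-yl in place of pyrimidin-2-yl on an aromatic carbon. Among the measured compounds shown here, only that one step bears on the change, and it shows that the ring with two nitrogens is where the gain lies; moving one nitrogen within that ring has no precedent here. Compound 3 is therefore expected near compound 2, with a step of a 2.5-fold higher number from compound 2 to compound 3 (0.40 log units; beyond the scatter), estimated at 150 nM within 40 nM to 600 nM.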

Compound 3, half-maximal inhibitory concentration: 1000 nM
For compound 3 the middle estimate is 6.7-fold (0.82 log units) below the measured one; measured number above the stated range.
By their numbers in this assay, from the lowest: compound 2; then compound 3; then compound 1.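

In this assay, the placing of the two ring nitrogens matters at this position, not only their presence: pyrazin-2-yl in place of pyrimidin-2-yl, with the same heavy atoms, loses most of the gain (a 17-fold higher number from compound 2 to compound 3 (1.22 log units; beyond the scatter)). Pyrazin-2-yl still stands ahead of phenyl (a 3.6-fold lower number from compound 1 to compound 3 (0.56 log units; beyond the scatter)), so part of the gain remains. No evidence at hand accounts for the difference between these two rings.

Open, on these data alone, is whether pyridin-2-yl, with one ring nitrogen, or pyrimidin-5-yl would side with compound 2 or compound 3. Also open, as far as these compounds go, is whether an amine on the pyrimidin-2-yl ring would be tolerated.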